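Swapping chlorines for methyls on a piperazine aryl ring

This account rests on a few compounds, and the source may have more. Where it says the series, first, only, none or still open, it means among the compounds named here.

Four compounds share one core. Compound 1 `c1coc(CNc2nc(NCCCN3CCCC3)nc3ccccc23)c1` has no result in a functional assay on MCF7 cells (Homo sapiens) for cytotoxicity, read by MTT assay, with a stated time of 2 days, tested at 10 uM (a higher number here means more inhibition at the concentration tested (going by the name of the read-out), a lower number less inhibition), so it is reported as "not determined" (no result reported). Compound 2 `CCCCCNc1nc(NCc2ccco2)c2cc(F)ccc2n1` carries a pentyl chain and a fluorine, and in this assay compound 2 gives 94.4%. Compound 3 `Clc1cccc(N2CCN(CCCCNc3nc(NCc4ccco4)c4ccccc4n3)CC2)c1Cl` replaces the pentyl chain with a butyl linker ending in a piperazine that bears a 2,3-dichlorophenyl group, and in this assay compound 3 gives 95.8%. The two numbers for compound 2 and compound 3 lie within the usual scatter of each other, so on the numbers shown compound 3 stands alongside compound 2 near the top of the scale, with no other measured value to compare against.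

Compound 4 `Cc1cccc(N2CCN(CCCCNc3nc(NCc4ccco4)c4ccccc4n3)CC2)c1C` is the next point and has not been measured. Its difference from compound 3 is counted as 2,3-dimethylphenyl in place of 2,3-dichlorophenyl on an amine nitrogen in a ring. For the measured compounds named here, no step between two measured compounds isolates this change, so the only guide is that compound 3 already sits close to the ceiling of the read-out. Compound 4 is therefore expected to land near compound 3, with a step of about a number 3.8 percentage points lower from compound 3 to compound 4 (within the scatter), which is within the scatter and no real move in either direction. The estimate for compound 4 in this assay is 92%, expected to fall between 75% and 99%.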

Compound 4, a percentage reported as inhibition, at one concentration (the size of the read-out at that concentration, not a potency): 95.8%
The estimate for compound 4 lay 3.8 percentage points below the measured number, within the range that was stated.
By their numbers in this assay, from the lowest: compounds 2, 3 and 4 (each within the scatter of the next).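

For the compounds shown here, replacing 2,3-dichlorophenyl with 2,3-dimethylphenyl on the amine nitrogen in the ring gives the first step between two measured compounds in this set, and this assay shows no change at the digits printed from compound 3 to compound 4 (within the scatter) for that swap. At this place, then, two chlorines and two methyl groups on the phenyl ring cannot be told apart by this read-out, even though the count of heavy atoms stays the same and only their element differs. The read-out gives the size of the effect at one concentration rather than a potency, so a difference in potency could stay hidden this high on the scale, and nothing measured here explains why the two groups read alike.

The compounds shown leave open how a phenyl ring bearing a carboxylic acid or an amine would read at this place, and whether a pyridine ring could stand in for the phenyl ring. They also leave open how a longer chain in place of the butyl linker would read in this assay when the 2,3-dimethylphenyl group is kept.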